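The source may hold more compounds than are shown below. What is called first, only, known or untested is meant among the compounds shown, and "the series" means these compounds.

Measured so far:
compound 1, `C[C@@H](NC(=O)[C@H](CCCNC(=N)N)NC(=O)c1ccc(CN(Cc2cccnc2)C(=O)c2ccc(F)cc2)cc1)c1cccc2ccccc12`: 11%
compound 2, `C[C@H](NC(=O)[C@H](CCCNC(=N)N)NC(=O)c1ccc(CN(Cc2ccc(F)cc2)Cc2cccnc2)cc1)c1cccc2ccccc12`: 27%
compound 3, `C[C@H](NC(=O)[C@H](CCCNC(=N)N)NC(=O)c1ccc(CN(Cc2ccccn2)C(=O)c2ccc(F)cc2)cc1)c1cccc2ccccc12`: 36%

In an assay on Jurkat cells for displacement of a labelled ligand from C-X-C chemokine receptor type 4 (Homo sapiens), tested at 10 uM (on this read-out lower numbers stand for less inhibition and higher numbers for more inhibition at the one concentration tested (going by the name of the read-out)), compound 3 gives the highest of the three numbers. Compound 2 gives 27%, which lies within the scatter of compound 3, so no order between these two can be read. Compound 1 gives 11%, beyond the scatter below compound 3. Compound 4, `C[C@H](NC(=O)[C@H](CCCNC(=N)N)NC(=O)c1ccc(CN(Cc2cccnc2)C(=O)c2ccc(F)cc2)cc1)c1cccc2ccccc12`, differs from compound 3 in one place: pyridin-3-yl in place of pyridin-2-yl on a saturated chain carbon bound to an amide-type nitrogen. No step between measured compounds matches this change, so its size is unknown; compound 1, which carries the pyridin-3-yl group on a different stereocentre, gives the lowest number shown. A modest fall is expected, a number 14 percentage points lower from compound 3 to compound 4 (beyond the scatter), possibly within the scatter. Compound 4 is estimated at 22%, between 5% and 40%.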

Compound 4, a percentage reported as inhibition, at one concentration (the size of the read-out at that concentration, not a potency): 14%
Beside the measured number, compound 4's estimate is 8 percentage points above it; measured number inside the range.
By their numbers in this assay, from the lowest: compounds 1 and 4 (each within the scatter of the next); then compounds 2 and 3 (each within the scatter of the next).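

Pyridin-3-yl in place of pyridin-2-yl on a saturated chain carbon bound to an amide-type nitrogen gives a number 22 percentage points lower from compound 3 to compound 4 (beyond the scatter), so this position responds to the change between these two pyridine groups. (4-Fluorophenyl)carbonyl in place of 4-fluorobenzyl on an amine nitrogen gives a number 13 percentage points lower from compound 2 to compound 4 (beyond the scatter), so the group on that nitrogen also matters when pyridin-3-yl is present. The stereocentre at a saturated chain carbon, drawn R in compound 1 and S in compound 4, gives a number 3 percentage points higher from compound 1 to compound 4 (within the scatter), so no effect of it can be read, and one caution applies to this pair: the fact that one of compounds 1 and 4 is drawn with a defined configuration and the other without, at the place where they differ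

From the compounds shown here alone, it remains open how pyridin-4-yl or a plain phenyl ring would compare at the same place. Also open, going by these compounds, is whether 4-fluorobenzyl on the amine nitrogen would have the same effect alongside pyridin-2-yl.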